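A few compounds are considered here, and "the series" means these few. Any claim that something is new, unique, unknown or untested is made for them only; others in the source may bear on it.

Of the compounds shown here, two have been tested in an ADME assay on HEL cells (Homo sapiens) for cytotoxicity, with a stated time of 3 days (a higher number here means that more compound is tolerated, a lower number that less compound is tolerated), so far. Compound 1 `CCC1(Cc2ccccc2)OS(=O)(=O)CC1=O` gives > 100000 nM, which is a limit of the assay rather than a measured number. Compound 2 `CCC1(Cc2ccccc2)OS(=O)(=O)C=C1OCc1ccccc1Cl` likewise gives only a limit, >= 20000 nM. Compound 2 therefore stands at one of the two limits shown, without a number of its own; the other value shown is a limit as well (the limit of > 100000 nM in this assay, at which 1 of the 2 values shown sits). Compound 3 `C=CCOC1=CS(=O)(=O)OC1(CC)Cc1ccccc1` has not yet been measured in this assay. It differs from compound 2 in one place: vinyl in place of 2-chlorophenyl on a saturated chain carbon bound to an oxygen on an unsaturated carbon. Among the compounds with values here, no step between two measured compounds is available, so the size of such a change cannot be read from the data. The step from compound 2 to compound 3 is expected to be a step that the limit leaves unreadable from compound 2 to compound 3, probably no more than the scatter. Compound 3 is expected to reach about 40000 nM in this assay, within a range from 20000 nM to 100000 nM.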

Compound 3, minimum cytotoxic concentration: 80000 nM
Beside the measured number, compound 3's estimate is 2.0-fold (0.30 log units) below it; measured number inside the range.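

Compound 2 gives only a limit of the assay, >= 20000 nM, and no size can be read for the change from compound 2 to compound 3. The compounds shown leave open whether allyl in place of 2-chlorobenzyl shifts the value in this assay at all, and by how much.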